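Adding a Nitro Group to a Scaffold Without Cytotoxicity

This account rests on a few compounds, and the source may have more. Where it says the series, first, only, none or still open, it means among the compounds named here.

Compound 1 `Cc1ccc2[nH]c(=O)c(-c3nc4ccccc4[nH]3)cc2c1` gives > 100000 nM in an ADME assay on L02 cells (Homo sapiens) for cytotoxicity, read by MTT assay, with a stated time of 48 h (on this read-out higher numbers stand for weaker inhibition and lower numbers for stronger inhibition), which is a limit of the assay and not a number.
Compound 2 `COc1ccc2[nH]c(=O)c(-c3nc4ccccc4[nH]3)cc2c1` gives > 100000 nM in this assay, again a limit.
Compound 3 `Cc1cc2nc(-c3cc4ccccc4[nH]c3=O)[nH]c2cc1C` gives > 100000 nM in this assay, also a limit.

Every measured value thus sits at the same limit, (the limit of > 100000 nM in this assay, at which 3 of the 3 values shown sit), and none of the three compounds reaches a measurable inhibitory concentration within the range tested. Among the measured compounds shown here, compound 2 stands at that limit, and the only single-point comparison available, a step that the two limits leave unreadable from compound 1 to compound 2, cannot be read. Compound 4 `COc1ccc2[nH]c(=O)c(-c3nc4cc([N+](=O)[O-])ccc4[nH]3)cc2c1` differs from compound 2 by one change: nitro in place of hydrogen on an aromatic carbon. For the measured compounds named here, no measured step involves a nitro group, and there is no direct guide to how this change affects the read-out; the measured compounds show only that the shared core, carrying methyl or methoxy, stays beyond the reach of the assay. The expectation for compound 4 is therefore that it behaves like its neighbours, with a step that the limit leaves unreadable from compound 2 to compound 4 expected to remain within the scatter. Compound 4 is estimated at 150000 nM. For compound 4 the expected range runs from 50000 nM to 500000 nM, most probably reported as a limit once more.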

Compound 4, half-maximal inhibitory concentration: > 100000 nM
Compound 4: a limit, no number (the forecaster's own chance of this, stated with the estimate: 75%); the middle value is on the limit's open side.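

Among the compounds shown here, compound 4, like compound 2, gives a limit and not a number, so no step between them can be read: the limit of > 100000 nM in this assay, at which 4 of the 4 values shown sit.

The compounds shown leave open at what concentration, if any, these cells would be affected, and whether nitro in place of hydrogen changes that.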